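Turning one double bond from E to Z

The compounds below may be only part of what the source reports. "The series", "measured", "known", "first", "only" and "open" are said of these compounds alone.

Numbers so far in a functional assay on P388 cells (Mus musculus) for inhibition (on this read-out higher numbers stand for weaker inhibition and lower numbers for stronger inhibition), for three compounds:
- compound 1 `COc1cc(/C=C\c2cn(C(C)=O)c3ccccc23)cc(OC)c1OC` gives 2850 nM
- compound 2 `COc1cc(/C=C\c2c[nH]c3ccccc23)cc(OC)c1OC` gives 3230 nM
- compound 3 `COc1cc(/C=C/c2cn(C)c3ccccc23)cc(OC)c1OC` gives 3090 nM

The number for compound 3 lies within the usual scatter of both others, so the three cannot be ranked. Compound 4 `COc1cc(/C=C\c2cn(C)c3ccccc23)cc(OC)c1OC` relates to compound 3 in one way only: the two compounds have the same atoms and bonds and differ only in configuration as drawn: 1 of 1 stereo elements differ; a double bond is drawn E in compound 3 and Z in compound 4. Among the measured compounds shown here, no measured pair isolates this change. For the measured compounds named here, the one measured step concerns a different place, hydrogen in place of acetyl on an aromatic nitrogen: a 1.1-fold higher number from compound 1 to compound 2 (0.05 log units; within the scatter) stays within the scatter. Indirect evidence comes from comparing across the double bond. Compound 2 has the Z form and gives 3230 nM while compound 3 has the E form and gives 3090 nM even though their nitrogen groups differ. A shift beyond the scatter in this assay is therefore not expected, although this rests on little data. The expected change is a 1.1-fold lower number from compound 3 to compound 4 (0.04 log units; within the scatter) and so has no clear direction. For compound 4 the estimate is 2800 nM with an expected range from 900 nM to 6000 nM for this measurement.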

Compound 4, half-maximal inhibitory concentration: 3090 nM
For compound 4 the middle estimate is 1.1-fold (0.04 log units) below the measured one; the range from low to high includes it.
By their numbers in this assay, from the lowest: compounds 1, 3, 4 and 2 (each within the scatter of the next).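

The comparison of the two forms of the double bond is clean here, and it rests on one thing: the fact that compounds 3 and 4 differ only in the configuration as drawn. In this assay, turning E into Z gives no change at the digits printed from compound 3 to compound 4 (within the scatter), so for this pair the drawn form of the double bond makes no difference that this measurement can detect. With the Z form held fixed, the group on the aromatic nitrogen also shows no effect beyond the scatter: methyl in place of hydrogen gives a 1.0-fold lower number from compound 2 to compound 4 (0.02 log units; within the scatter), and methyl in place of acetyl gives a 1.1-fold higher number from compound 1 to compound 4 (0.04 log units; within the scatter).

The compounds shown leave open whether the same flat picture would hold with a longer chain, an amine or a carboxylic acid on that nitrogen. They also leave open whether the form of the double bond would count once the methoxy groups of the shared core are replaced.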